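Methyl to Bromo on the Aryl Group: Cytotoxicity

The source may report more compounds than this note shows. Statements on the series, on what has been measured and on what is new or still open speak of the compounds shown alone.

Compound 1, `COc1ccc(-c2noc(CN3N=N[C@@H]4C(=O)N(c5ccccc5)C(=O)[C@@H]43)n2)cc1`: > 100 ug/mL, a limit of the assay.
Compound 2, `Cc1ccc(-c2noc(CN3N=N[C@@H]4C(=O)N(c5ccccc5)C(=O)[C@@H]43)n2)cc1`: 15.2 ug/mL.

In an ADME assay on L6 cells (Rattus norvegicus) for cytotoxicity, read by resazurin assay, with a stated time of 72 h (on this read-out higher numbers stand for weaker inhibition and lower numbers for stronger inhibition), compound 1 gives only > 100 ug/mL, a limit rather than a number. Compound 2 gives 15.2 ug/mL, the only number shown, since the other value sits at the limit of > 100 ug/mL in this assay, at which 1 of the 2 values shown sits. For the measured compounds named here, the sole measured step is an at least 6.5-fold lower number from compound 1 to compound 2 (0.81 log units; beyond the scatter), from a methoxy to a methyl. Compound 3, `O=C1[C@H]2N=NN(Cc3nc(-c4ccc(Br)cc4)no3)[C@H]2C(=O)N1c1ccccc1`, differs from compound 2 by bromo in place of methyl on an aromatic carbon. Going by the values given here, no measured step covers bromo in place of methyl, so the expected step of a 1.0-fold lower number from compound 2 to compound 3 (0.01 log units; within the scatter) is none beyond the scatter. Compound 3 is thus estimated at 15 ug/mL, between 5 ug/mL and 45 ug/mL.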

Compound 3, half-maximal inhibitory concentration: 58.6 ug/mL
Compound 3: middle estimate off by 3.9-fold (0.59 log units), on the low side; measured number outside the range, above it.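

Methyl is not interchangeable with bromo at this place on the ring: in this assay, the swap of one heavy atom for another gives a 3.9-fold higher number from compound 2 to compound 3 (0.59 log units; beyond the scatter), so the 4-methylphenyl of compound 2 carries the lowest number of the three. Bromo in place of methoxy gives an at least 1.7-fold lower number from compound 1 to compound 3 (0.23 log units; that floor lies within the scatter), and that floor does not separate the two groups. Compound 1 stands at a limit, so this step has no upper bound: the limit of > 100 ug/mL in this assay, at which 1 of the 3 values shown sits.

As far as these compounds go, how an amine, a carboxylic acid or a longer chain would read at this place stays open. So does whether compound 2 is an isolated case.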